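Replacing bromo with ethoxy on the pyrazine hydrazone scaffold

A few compounds are considered here, and "the series" means these few. Any claim that something is new, unique, unknown or untested is made for them only; others in the source may bear on it.

Of the compounds shown here, three that share one core have been measured in an ADME assay on J774 cells (Mus musculus) for cytotoxicity, read by MTT assay, with a stated time of 48 h, tested at 100 ug/mL; on this read-out lower numbers stand for a stronger effect and higher numbers for a weaker effect at the one concentration tested. Compound 1 `O=C(N/N=C/c1ccccc1)c1cnccn1` gives 75%. Compound 2 `O=C(N/N=C/c1cccc(F)c1)c1cnccn1` gives 46%. Compound 3 `O=C(N/N=C/c1cccc(Br)c1)c1cnccn1` gives 100%, the highest of the three numbers, and both of its steps from the others lie beyond the scatter: a number 25 percentage points higher from compound 1 to compound 3 (beyond the scatter) and a number 54 percentage points higher from compound 2 to compound 3 (beyond the scatter). Compound 4 `CCOc1cccc(/C=N/NC(=O)c2cnccn2)c1` is not yet measured; it differs from compound 3 by ethoxy in place of bromo on an aromatic carbon. Among the measured compounds shown here, no measured step introduces ethoxy, so the only guide is that the bromo which departs here has, in both measured steps toward compound 3, come with higher numbers, and that the other step between the measured compounds, a number 29 percentage points lower from compound 1 to compound 2 (beyond the scatter), shows that a small change at the same aromatic carbon moves this assay by a modest amount. The estimate for compound 4 is therefore a number below compound 3, a step of a number 30 percentage points lower from compound 3 to compound 4 (beyond the scatter), expected at 70% with a range from 45% to 100%.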

Compound 4, a percentage reported as activity, at one concentration (the size of the read-out at that concentration, not a potency): 71%
Compound 4: middle estimate off by 1 percentage points, on the low side; measured number inside the range.
By their numbers in this assay, from the lowest: compound 2; then compounds 4 and 1 (each within the scatter of the next); then compound 3.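

In this assay this aromatic carbon now carries a group other than a halogen, and ethoxy in place of bromo gives a number 29 percentage points lower from compound 3 to compound 4 (beyond the scatter) and so does not share the high number that bromo brought. Set against the unsubstituted parent, ethoxy gives a number 4 percentage points lower from compound 1 to compound 4 (within the scatter) and cannot be told apart from hydrogen at this position, while ethoxy in place of fluoro gives a number 25 percentage points higher from compound 2 to compound 4 (beyond the scatter) and leaves the fluoro compound with the lowest number of the set. Nothing available explains why these groups differ.

The compounds shown leave open whether the ethoxy result would hold for a hydroxy group, a methoxy group or a longer alkoxy chain at this carbon. They also leave open how an amine or a carboxylic acid would read here.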